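This account rests on a few compounds, and the source may have more. Where it says the series, first, only, none or still open, it means among the compounds named here.

Compounds measured so far:
compound 1 `Cc1nc(N(C)c2ccc([Se]C#N)c(Cl)c2)c2ccccc2n1`, 12 nM
compound 2 `C[Se]c1ccc(N(C)c2nc(C3CC3)nc3ccccc23)cc1`, 15 nM
compound 3 `COc1ccc(N(C)c2nc(C)nc3ccccc23)cc1OCCCCC[Se]C#N`, 256 nM

In a functional assay on HCT-116 cells (Homo sapiens) for inhibition, read by MTT assay, with a stated time of 48 h (on this read-out higher numbers stand for weaker inhibition and lower numbers for stronger inhibition), compound 3 gives 256 nM, the highest of the three numbers. Compound 2, the nearest, gives 15 nM, a lower number beyond the scatter, and compound 1, the furthest, gives 12 nM, also lower and beyond the scatter. Compound 4 `COc1ccc(N(C)c2nc(C)nc3ccccc23)cc1OCCCC[Se]C#N` has not been measured. It differs from compound 3 in one place: a group of 3 heavy atoms (1 carbon, 1 nitrogen, 1 selenium; no ring) in place of a group of 4 heavy atoms (2 carbon, 1 nitrogen, 1 selenium; no ring), on a saturated chain carbon, four bonds along the chain from an oxygen on an aromatic ring. Among the compounds with values here, no step between measured compounds resembles this change, so the expectation rests on compound 3 alone. The step of a 1.0-fold lower number from compound 3 to compound 4 (0.01 log units; within the scatter) is expected to be small, with no clear direction and not beyond the scatter. Compound 4 is thus estimated at 250 nM, within a range from 90 nM to 700 nM.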

Compound 4, half-maximal inhibitory concentration: 512 nM
Compound 4: middle estimate off by 2.0-fold (0.31 log units), on the low side; low and high end bracket the measured number.
By their numbers in this assay, from the lowest: compounds 1 and 2 (each within the scatter of the next); then compounds 3 and 4 (each within the scatter of the next).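

In this assay, a group of 3 heavy atoms in place of a group of 4 heavy atoms, on a saturated chain carbon, four bonds along the chain from an oxygen on an aromatic ring, gives a 2.0-fold higher number from compound 3 to compound 4 (0.30 log units; within the scatter). Within the data shown here, this is the first step that can be read between two measured compounds, and it shows that this change at this place does not move the number beyond the scatter. Nothing measured here bears on this result. As far as these compounds go, what a longer chain at this place would give stays open, and so does the effect of an amine or a carboxylic acid on this chain.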